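Hydroxamate versus aminoanilide zinc binder on a shared benzylamine scaffold

This account rests on a few compounds, and the source may have more. Where it says the series, first, only, none or still open, it means among the compounds named here.

Compound 1 `Nc1ccccc1NC(=O)c1ccc(CNC2=NC(=O)C(c3ccccc3)N2)cc1`: 8000 nM
Compound 2 `Nc1ccccc1NC(=O)c1ccc(CNC2=NC(=O)C(Cc3c[nH]c4ccccc34)N2)cc1`: > 20000 nM
Compound 3 `O=C(NO)c1ccc(CNc2nccc(-c3cccnc3)n2)cc1`: 410 nM

Of the compounds shown here, three have been measured in an assay for inhibition of histone deacetylase 8 (Homo sapiens), read by fluorescence, with stated times of 15 min and 60 min; on this read-out higher numbers stand for weaker inhibition and lower numbers for stronger inhibition. Compound 3 gives the lowest number of the set, and its nearest neighbour, compound 1, gives 8000 nM, a gap that lies well beyond the scatter. The value of compound 2 in this assay is a limit, not a number, at the limit of > 20000 nM in this assay, at which 1 of the 3 values shown sits. Among the measured compounds shown here, the one measured step, an at least 2.5-fold higher number from compound 1 to compound 2 (0.39 log units; beyond the scatter), concerns a change on a saturated ring carbon and does not bear on what follows.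

Compound 4 `Nc1cc(O)ccc1NC(=O)c1ccc(CNc2nccc(-c3cccnc3)n2)cc1` has not yet been measured. It differs from compound 3 by 2-amino-4-hydroxyphenyl in place of hydroxy on an amide-type nitrogen. For the measured compounds named here, no measured step follows this exact change. What the data show is that the two compounds carrying an aminophenyl amide, compound 1 and compound 2, give the two high values, whereas compound 3 with its hydroxy on the amide nitrogen gives the low one. On that basis a large rise in the number is expected, with a fair chance that only a limit is returned.

Compound 4 is expected to give about 8000 nM in this assay, within a range from 1500 nM to 30000 nM. This estimate corresponds to a 20-fold higher number from compound 3 to compound 4 (1.29 log units; beyond the scatter).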

Compound 4, half-maximal inhibitory concentration: > 20000 nM
Compound 4 was reported as a limit (the forecaster's own chance of this, stated with the estimate: 30%); middle value at least 2.5-fold (0.39 log units) away from the limit.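

Replacing hydroxy with 2-amino-4-hydroxyphenyl on the amide-type nitrogen gives an at least 48-fold higher number from compound 3 to compound 4 (1.68 log units; beyond the scatter) in this assay. Among the compounds shown here, this is the first comparison of the two groups with the rest of the structure held the same, and it shows that on this core the change alone is enough to produce a large step towards weaker inhibition, which the earlier contrast with compound 1 and compound 2, whose cores differ, could only suggest. The value of compound 4, > 20000 nM, is a limit and not a number, and with it a second compound now sits at the same limit: the limit of > 20000 nM in this assay, at which 2 of the 4 values shown sit.

The compounds shown leave open how the number would respond to other groups on the amide-type nitrogen, such as a methoxy group or a plain amine, and so how much of the step belongs to losing the hydroxy and how much to the 2-amino-4-hydroxyphenyl that enters. They also leave open whether the same exchange on the core of compound 1 would give a step of similar size.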